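Amine exchange on the side chain of compound 2

The compounds below may be only part of what the source reports. "The series", "measured", "known", "first", "only" and "open" are said of these compounds alone.

Compound 1 `COc1c(OCc2cnoc2C)cc(O)c2c(=O)cc(-c3ccccc3)oc12` and compound 2 `COc1c(OCCCCN2CCCC2)cc(O)c2c(=O)cc(-c3ccccc3)oc12` share a core and differ in one side chain. In a functional assay on A549 cells (Homo sapiens) for cytotoxicity, read by MTT assay, with a stated time of 48 h (on this read-out lower numbers stand for stronger inhibition and higher numbers for weaker inhibition), compound 1 gives > 100000 nM, which is a limit of the assay and not a number. Going by the values given here, compound 2 gives 1530 nM, the only true number so far in this assay. Among the compounds with values here, the one measured step is large: an at least 65-fold lower number from compound 1 to compound 2 (1.81 log units; beyond the scatter).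

Compound 3 `COc1c(OCCCN2CCN(C)CC2)cc(O)c2c(=O)cc(-c3ccccc3)oc12` keeps the core and changes the end of the chain: 4-methylpiperazin-1-yl in place of (pyrrolidin-1-yl)methyl on a saturated chain carbon, three bonds along the chain from an oxygen on an aromatic ring. In words, 4-methylpiperazin-1-yl stands in place of (pyrrolidin-1-yl)methyl on a saturated chain carbon, three bonds along the chain from an oxygen on an aromatic ring. Within the data shown here, no measured step covers this exchange directly. The step from compound 1 bears on it only loosely, as it replaced 5-methyl-1,2-oxazol-4-yl, not one non-aromatic ring with another. Compound 3 still ends in a non-aromatic ring holding nitrogen, so a change the size of an at least 65-fold lower number from compound 1 to compound 2 (1.81 log units; beyond the scatter) is not expected. The expected step, a 1.8-fold higher number from compound 2 to compound 3 (0.26 log units; within the scatter), is small, may stay within the scatter, and leans toward a higher number. For compound 3 the estimated value in this assay is 2800 nM, with an expected range of 900 nM to 10000 nM.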

Compound 3, half-maximal inhibitory concentration: 9900 nM
The estimate for compound 3 lay 3.5-fold (0.55 log units) below the measured number, and the stated range covers the measured number.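

Notes on the side chain

In this assay, keeping a non-aromatic ring holding nitrogen at the end of the chain does not make the end group interchangeable: 4-methylpiperazin-1-yl in place of (pyrrolidin-1-yl)methyl gives a 6.5-fold higher number from compound 2 to compound 3 (0.81 log units; beyond the scatter). This one exchange also alters the ring and the chain together, as the same difference reads 4-(pyrrolidin-1-yl)butyl to 3-(4-methylpiperazin-1-yl)propyl, and the side chain of compound 3 still gives an at least 10-fold lower number from compound 1 to compound 3 (1.00 log units; beyond the scatter). That last step has no fixed size, since compound 1 gives a limit and not a number: the limit of > 100000 nM in this assay, at which 1 of the 3 values shown sits.

The compounds shown leave open how much of the loss from compound 2 to compound 3 belongs to the ring and how much to the chain; a 4-(4-methylpiperazin-1-yl)butyl or a 3-(pyrrolidin-1-yl)propyl group on the same oxygen would separate the two. They also leave open whether the trend holds for other chain ends, such as morpholin-4-yl, piperidin-1-yl or an open-chain dimethylamino group.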